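The source may report more compounds than this note shows. Statements on the series, on what has been measured and on what is new or still open speak of the compounds shown alone.

In an ADME assay on microsomes from liver (Mus musculus, strain CD1) for metabolic stability, read by HPLC, using NADPH, with a stated time of 30 min, tested at 0.5 uM (on this read-out lower numbers stand for slow clearance and higher numbers for fast clearance), compound 1 (`CC(=O)Nc1cnc2[nH]c(=O)n([C@H]3CC[C@@H](C(C)(C)C)CC3)c(=O)c2c1`) gives 15 mL.min-1.g-1, while compound 2 (`CC(C)(C)[C@H]1CC[C@H](n2c(=O)[nH]c3ncc(N)cc3c2=O)CC1`) gives 0.5 mL.min-1.g-1, the lower of the two numbers and beyond the usual scatter. Compound 3 (`CC(C)(C)[C@H]1CC[C@@H](n2c(=O)[nH]c3ncc(N)cc3c2=O)CC1`) changes only the spatial arrangement of compound 2: the two compounds have the same atoms and bonds and differ only in configuration as drawn: 2 of 2 stereo elements differ (all stereocentres are inverted: mirror images); a stereocentre at a saturated ring carbon is drawn r in compound 2 and s in compound 3; a stereocentre at a saturated ring carbon is drawn r in compound 2 and s in compound 3. Going by the values given here, no measured pair shows what such a change does in this assay, so any forecast is uncertain, though a modest rise is expected since compound 2 gives 0.5 mL.min-1.g-1. The expected change is a 3.0-fold higher number from compound 2 to compound 3 (0.48 log units; beyond the scatter). For compound 3 the estimated value is 1.5 mL.min-1.g-1, with an expected range of 0.4 mL.min-1.g-1 to 6 mL.min-1.g-1.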

Compound 3, intrinsic clearance in microsomes: 1.6 mL.min-1.g-1
Estimate against measurement, compound 3: 1.1-fold (0.03 log units) below, and the stated range covers the measured number.
By their numbers in this assay, from the lowest: compound 2; then compound 3; then compound 1.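

In this assay the arrangement in space alone moves the number, with a 3.2-fold higher number from compound 2 to compound 3 (0.51 log units; beyond the scatter), so the same atoms and bonds do not guarantee the same clearance. Only that arrangement can account for this gap: the fact that compounds 2 and 3 differ only in the configuration as drawn. With hydrogen in place of acetyl on a nitrogen on an aromatic ring, the larger change is a 9.4-fold lower number from compound 1 to compound 3 (0.97 log units; beyond the scatter), so this nitrogen matters more here than the configuration does. On these data alone, whether a methyl group or a longer acyl chain on that nitrogen would fall nearer compound 3 or compound 1 remains open.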